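The source may report more compounds than this note shows. Statements on the series, on what has been measured and on what is new or still open speak of the compounds shown alone.

Of the compounds shown here, three sharing one core have been measured in a functional assay on DU-145 cells (Homo sapiens) for cytotoxicity, read by MTT assay; on this read-out lower numbers stand for stronger inhibition and higher numbers for weaker inhibition. Compound 1, `CC(C)=CC[C@@H](OC(=O)CCO)C1=CC(=O)c2c(O)ccc(O)c2C1=O`, gives 55300 nM. Compound 2, `CC(=O)OCCC(=O)O[C@H](CC=C(C)C)C1=CC(=O)c2c(O)ccc(O)c2C1=O`, gives 15700 nM and so stands lowest of the three numbers. Compound 3, `COCCO[C@H](CC=C(C)C)C1=CC(=O)c2c(O)ccc(O)c2C1=O`, gives 43200 nM. The step of a 3.5-fold lower number from compound 1 to compound 2 (0.55 log units; beyond the scatter) and the step of a 2.8-fold higher number from compound 2 to compound 3 (0.44 log units; beyond the scatter) both concern the chain on the ester oxygen and both lie beyond the scatter, while a 1.3-fold lower number from compound 1 to compound 3 (0.11 log units; within the scatter) stays within it. Compound 4, `CC(C)=CC[C@@H](OC(=O)CC(C)(O)C(C)C)C1=CC(=O)c2c(O)ccc(O)c2C1=O`, differs from compound 2 in that same chain: 1-hydroxy-1,2-dimethylpropyl in place of acetoxymethyl on a saturated chain carbon bound to a carbonyl carbon. Among the compounds with values here, the acetyl that sets compound 2 apart from compound 1 is thus gone again, and the entering 1-hydroxy-1,2-dimethylpropyl group belongs to no measured compound. Within the data shown here, on this evidence the number for compound 4 is expected to move back up toward that of compound 1, because a 3.5-fold lower number from compound 1 to compound 2 (0.55 log units; beyond the scatter) was the one step that came with the acetyl, though the new branched chain leaves the size uncertain. The expected step is a 2.0-fold higher number from compound 2 to compound 4 (0.31 log units; beyond the scatter). Compound 4 is expected to give 32000 nM, with a range from 12000 nM to 80000 nM.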

Compound 4, half-maximal inhibitory concentration: 16900 nM
The estimate for compound 4 lay 1.9-fold (0.28 log units) above the measured number, within the range that was stated.
By their numbers in this assay, from the lowest: compounds 2 and 4 (each within the scatter of the next); then compounds 3 and 1 (each within the scatter of the next).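

In this assay, within the data shown here, putting 1-hydroxy-1,2-dimethylpropyl in place of acetoxymethyl on a saturated chain carbon bound to a carbonyl carbon gives a step within the scatter (a 1.1-fold higher number from compound 2 to compound 4 (0.03 log units; within the scatter)), so the acetyl is not the only group at this place that goes with the lower numbers. A free hydroxyl in the chain does not by itself hold the number up, since the hydroxymethyl and 1-hydroxy-1,2-dimethylpropyl chains, both bearing one, lie beyond the scatter of each other (a 3.3-fold lower number from compound 1 to compound 4 (0.51 log units; beyond the scatter)), and the step from the 2-methoxyethyl group is also beyond it (a 2.6-fold lower number from compound 3 to compound 4 (0.41 log units; beyond the scatter)). Nothing at hand explains these differences.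

The compounds shown do not separate the hydroxyl of the new group from its branched carbons, which a 1,2-dimethylpropyl group without the hydroxyl would address. As far as these compounds go, it also remains open how an amine or a carboxylic acid at this place would read.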